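This account rests on a few compounds, and the source may have more. Where it says the series, first, only, none or still open, it means among the compounds named here.

In a functional assay on KB 3-1 cells (Homo sapiens) for cytotoxicity, read by MTT assay, with a stated time of 68 h (on this read-out lower numbers stand for stronger inhibition and higher numbers for weaker inhibition), compound 1 `O=C(Nc1cccc(-c2ccsc2)c1)C(Cl)Cl` gives > 50000 nM, which is a limit of the assay. Compound 2 `O=C(Nc1cccc(-c2ccc(C(F)(F)F)cc2)c1)C(Cl)Cl` gives > 50000 nM, also a limit, so compound 2 has no exact number. Going by the values given here, the series so far stands at the limit of > 50000 nM in this assay, at which 2 of the 2 values shown sit. Compound 3 `O=C(Nc1cccc(-c2ccccc2)c1)C(Cl)Cl` differs from compound 2 by hydrogen in place of trifluoromethyl on an aromatic carbon. Among the compounds with values here, no step between measured compounds is available to guide the expectation. The estimated change is a number no higher from compound 2 to compound 3 (the limit leaves the size open), expected to be nothing beyond the usual scatter. For compound 3 the expected value is 50000 nM, with an estimated range of 25000 nM to 100000 nM.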

Compound 3, half-maximal inhibitory concentration: 46800 nM
The estimate for compound 3 lay 1.1-fold (0.03 log units) above the measured number; the range from low to high includes it.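

In this assay, going by these compounds alone, compound 3 gives 46800 nM as the first exact number of the series, with hydrogen on the aromatic carbon para to a large group. Hydrogen in place of trifluoromethyl gives an at least 1.0-fold lower number from compound 2 to compound 3 (0.02 log units; that floor lies within the scatter) and phenyl in place of thiophen-3-yl gives an at least 1.0-fold lower number from compound 1 to compound 3 (0.02 log units; that floor lies within the scatter) but both steps start from a limit, so their true size stays open. Most of the series still rests on that limit: the limit of > 50000 nM in this assay, at which 2 of the 3 values shown sit.

On these data alone, whether any group on this aromatic carbon moves the number clearly away from that limit remains open. An amine or a carboxylic acid in place of the hydrogen would test this on the shared core.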